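From Benzyl to Ethyl at the Limit of the Assay

The source may hold more compounds than are shown below. What is called first, only, known or untested is meant among the compounds shown, and "the series" means these compounds.

In a functional assay on MCF7 cells (Homo sapiens) for inhibition (on this read-out higher numbers stand for weaker inhibition of growth and lower numbers for stronger inhibition of growth), compound 1 (`COC(=O)c1ccsc1NC(=O)[C@@H]1CCCN1`) gives > 250 ug/mL, which is a limit and not a measured number. Compound 2 (`O=C(OCc1ccccc1)c1ccsc1NC(=O)[C@@H]1CCCN1`) gives > 250 ug/mL, and this too is only a limit. Compound 2 therefore has no exact position on the scale. For the measured compounds named here, the one measured step, a step that the two limits leave unreadable from compound 1 to compound 2, has a limit at both ends, so its size cannot be read. Both compounds share one result: the limit of > 250 ug/mL in this assay, at which 2 of the 2 values shown sit.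

Compound 3 (`CCOC(=O)c1ccsc1NC(=O)[C@@H]1CCCN1`) is reached from compound 2 by a single change: methyl in place of phenyl on a saturated chain carbon bound to an oxygen next to a carbonyl group. This places methyl in place of phenyl on a saturated chain carbon bound to an oxygen next to a carbonyl group, which also reads as benzyl to ethyl. That carbon bears hydrogen in compound 1 and phenyl in compound 2, and neither compound gives a number, with compound 2 at > 250 ug/mL.

The expected change, a step that the limit leaves unreadable from compound 2 to compound 3, is no step beyond the scatter in either direction. For compound 3, the estimated value is 300 ug/mL, within an expected range of 180 ug/mL to 500 ug/mL.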

Compound 3, concentration for 50% growth inhibition: > 250 ug/mL
Compound 3: a limit, no number (the forecaster's own chance of this, stated with the estimate: 85%); the middle value is on the limit's open side.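

No new step can be read among compound 1, compound 2 and compound 3, since each gives only a limit and not a number, so the steps between them stay unreadable: the limit of > 250 ug/mL in this assay, at which 3 of the 3 values shown sit.

On these data alone, whether hydrogen, methyl or phenyl on that chain carbon makes any difference to growth inhibition in this assay remains open.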